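This account rests on a few compounds, and the source may have more. Where it says the series, first, only, none or still open, it means among the compounds named here.

Of the compounds shown here, three have already been measured in a functional assay on L5178Y cells (Mus musculus) for antiproliferative activity, read by MTT assay; on this read-out lower numbers stand for stronger inhibition and higher numbers for weaker inhibition. Compound 1 `CC(=O)c1ccc(OCCCN2CCN(c3ncccn3)CC2)cc1` gives 53.2 nM, compound 2 `CC(C)(C)c1ccc(OCCCN2CCN(c3ncccn3)CC2)cc1` gives 25.6 nM, and compound 3 `CC(=O)c1ccc(OCCCCN2CCN(c3ccccn3)CC2)cc1` gives 24.1 nM. Compounds 1 and 2 share a core and differ in one place, described by tert-butyl in place of acetyl on an aromatic carbon; this change brought a 2.1-fold lower number from compound 1 to compound 2 (0.32 log units; beyond the scatter). Compound 3 carries a different core, and the difference between the two cores is not broken down here. Of the three measured numbers, compound 3 has the lowest, but its gap to compound 2 lies within the usual scatter of this assay, so no order between those two can be read.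

Compound 4 `CC(C)(C)c1ccc(OCCCCN2CCN(c3ccccn3)CC2)cc1` has not yet been measured. It stands to compound 3 exactly as compound 2 stands to compound 1, through (tert-butyl in place of acetyl on an aromatic carbon), the same change made at the same kind of place. For the measured compounds named here, for this reason a similar step is expected, roughly a 1.9-fold lower number from compound 3 to compound 4 (0.27 log units; within the scatter), resting on the single earlier example a 2.1-fold lower number from compound 1 to compound 2 (0.32 log units; beyond the scatter) and on compound 3 starting from 24.1 nM. On that basis compound 4 is estimated at 13 nM, likely between 6 nM and 28 nM.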

Compound 4, half-maximal inhibitory concentration: 11.9 nM
Compound 4: middle estimate off by 1.1-fold (0.04 log units), on the high side, and the stated range covers the measured number.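

In this assay, placing tert-butyl where acetyl stood gave a 2.0-fold lower number from compound 3 to compound 4 (0.31 log units; beyond the scatter), and this step matches the earlier one, so the change carried over from the core of compound 1 to the core of compound 3 with its size essentially unchanged: the same change on two cores in this assay, a 2.1-fold lower number (0.32 log units; beyond the scatter) from compound 1 to compound 2 and a 2.0-fold lower number (0.31 log units; beyond the scatter) from compound 3 to compound 4, 1.0-fold (0.01 log units) apart, within the scatter of two such steps Within these four compounds, then, the effect of the swap did not depend on which of the two cores carried it, and the result on one core was a fair guide to the result on the other. For the compounds shown here, this rests on only two pairs in a single cell assay, however, so it does not show why the number falls, nor that the same step would appear on a third core.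

The compounds shown leave open what other groups on that aromatic carbon would do, such as an amine, a carboxylic acid or trifluoromethyl. They also leave open whether the step would hold on a core with a longer chain.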